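Furan Hydrazone in Place of a Free Amino Group

A few compounds are considered here, and "the series" means these few. Any claim that something is new, unique, unknown or untested is made for them only; others in the source may bear on it.

Compound 1 `CC1=CC[C@H](C(C)(C)NC(=S)NN)CC1` carries a thiosemicarbazide whose terminal nitrogen is a free amino group. In a functional assay on NCI-H460 cells (Homo sapiens) for inhibition, read by sulforhodamine B assay, with a stated time of 48 h (on this read-out lower numbers stand for stronger inhibition of growth and higher numbers for weaker inhibition of growth), compound 1 gives only > 100000 nM, which is a limit of the assay and not a number, so compound 1 stands at the limit of > 100000 nM in this assay, at which 2 of the 3 values shown sit. Compound 2 `CC1=CC[C@H](C(C)(C)NC(=S)N/N=C/c2ccccc2)CC1` condenses that amino group with a benzaldehyde to a hydrazone, and in this assay compound 2 gives 53900 nM. Compound 3 `CC1=CC[C@H](C(C)(C)NC(=S)N/N=C/c2ccc(F)cc2)CC1` carries fluoro in place of hydrogen on an aromatic carbon of that hydrazone; in this assay compound 3 gives > 100000 nM, again a limit of the assay. For the measured compounds named here, the only measured step, an at least 1.8-fold higher number from compound 2 to compound 3 (0.26 log units; that floor lies within the scatter), therefore ends at the floor of the assay. Compound 4 `CC1=CC[C@H](C(C)(C)NC(=S)N/N=C/c2ccco2)CC1` carries a furan-based hydrazone instead of the amino group of compound 1: a group of 7 heavy atoms (5 carbon, 1 nitrogen, 1 oxygen; one five-membered aromatic ring with 1 hetero atom) in place of one nitrogen atom, on an amide-type nitrogen. Going by the values given here, no measured step covers this exact change; compound 2 and compound 3 show only that hydrazones of this kind stay weak, one at a number and one at a limit. Compound 4 is expected to land in that weak region, a step of an at least 1.2-fold lower number from compound 1 to compound 4 (0.09 log units; that floor lies within the scatter) that cannot be sized against a limit. The estimate for compound 4 is 80000 nM, between 30000 nM and 200000 nM.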

Compound 4, concentration for total growth inhibition: 10800 nM
The estimate for compound 4 lay 7.4-fold (0.87 log units) above the measured number, outside the stated range (below it).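

Furan-2-yl in place of phenyl on a carbon with a double bond to nitrogen gives a 5.0-fold lower number from compound 2 to compound 4 (0.70 log units; beyond the scatter) in this assay, so changing the ring on the hydrazone can shift growth inhibition, and this is the one new step measured between two real numbers. The other two steps, an at least 9.2-fold lower number from compound 1 to compound 4 (0.96 log units; beyond the scatter) and an at least 9.2-fold lower number from compound 3 to compound 4 (0.96 log units; beyond the scatter), are also printed as beyond the scatter, which makes compound 4 the strongest of the four compounds shown. Those two steps are only floors, since each starts from a limit of the assay and not a number: the limit of > 100000 nM in this assay, at which 2 of the 4 values shown sit.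

The compounds shown leave open whether this shift is specific to furan, which a thiophene or pyridine ring on the same hydrazone would test. They also leave open how a methyl group on the furan ring, or a carbonyl in place of the thiocarbonyl, would change the number.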